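Hydroxyl groups replace methoxy groups on the imine-linked phenyl

A few compounds are considered here, and "the series" means these few. Any claim that something is new, unique, unknown or untested is made for them only; others in the source may bear on it.

Of the compounds shown here, two have been measured. Compound 1 `CCCCc1oc2ccc(/N=C/c3ccc(OC)cc3OC)cc2c1C(=O)c1ccc(OC)cc1` gives 20.5 ug/mL in a functional assay, with a stated time of 30 min (a higher number here means a weaker inhibitor, a lower number a stronger inhibitor), and compound 2 `CCCCc1oc2ccc(/N=C/c3ccccc3)cc2c1C(=O)c1ccc(OC)cc1` gives 34.2 ug/mL. Compound 2 is separated from compound 1 only by a 1.7-fold higher number from compound 1 to compound 2 (0.22 log units; within the scatter), so the two stand together within the scatter. Compound 3 `CCCCc1oc2ccc(/N=C/c3ccc(O)cc3O)cc2c1C(=O)c1ccc(OC)cc1` carries 2,4-dihydroxyphenyl in place of phenyl on a carbon with a double bond to nitrogen. Going by the values given here, the single step that bears on this site, from the 2,4-dimethoxyphenyl of compound 1 to the phenyl of compound 2, stayed within the scatter, so no step beyond the scatter is expected for a 1.4-fold lower number from compound 2 to compound 3 (0.14 log units; within the scatter) either. Compound 3 is therefore estimated at 25 ug/mL, expected between 10 ug/mL and 60 ug/mL.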

Compound 3, half-maximal inhibitory concentration: 7.55 ug/mL
Estimate against measurement, compound 3: 3.3-fold (0.52 log units) above; the measured number lies below the stated range.
By their numbers in this assay, from the lowest: compound 3; then compounds 1 and 2 (each within the scatter of the next).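

On a carbon with a double bond to nitrogen, 2,4-dihydroxyphenyl gives the strongest inhibitor of the three in this assay, with a 4.5-fold lower number from compound 2 to compound 3 (0.66 log units; beyond the scatter) and a 2.7-fold lower number from compound 1 to compound 3 (0.43 log units; beyond the scatter). This site therefore does respond to the ring it carries, and hydroxyl groups separate from methoxy groups on the same ring, which the step between phenyl and 2,4-dimethoxyphenyl had not shown. Nothing measured here explains the difference. As far as these compounds go, whether both hydroxyl groups are needed remains open, since no ring with a single hydroxyl appears. Nor is it shown how an amine or a carboxylic acid on this ring would compare.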